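Adding a Second Hydroxyl to an Almost Inactive Chain

This account rests on a few compounds, and the source may have more. Where it says the series, first, only, none or still open, it means among the compounds named here.

Compound 2 `CC(O)CCn1nc2c(Br)c(Br)c(Br)c(Br)c2n1` and compound 1 `C[C@@H](O)CCn1nc2c(Br)c(Br)c(Br)c(Br)c2n1` share one core and differ only in how one stereocentre is drawn. In a functional assay on CCRF-CEM cells (Homo sapiens) for antiproliferative activity, read by MTT assay, with a stated time of 48 h, tested at 12.5 uM (on this read-out higher numbers stand for a weaker effect at the one concentration tested and lower numbers for a stronger effect), compound 2 gives 94%, and compound 1 gives 94%; the step of no change at the digits printed from compound 1 to compound 2 (within the scatter) is within the scatter, which fits (the fact that one of compounds 1 and 2 is drawn with a defined configuration and the other without, at the place where they differ). Both numbers sit near the top of the scale, meaning little effect on these cells. Compound 3 `OCC(O)Cn1nc2c(Br)c(Br)c(Br)c(Br)c2n1` changes the chain: 1,2-dihydroxyethyl in place of 2-hydroxypropyl on a saturated chain carbon bound to an aromatic nitrogen. Among the compounds with values here, no measured step involves adding or removing a hydroxyl, so the one known step, which concerns drawn stereochemistry only, gives no guide to this change. With compound 2 already close to no effect, the room for a weaker result is small, and nothing in the data points to a stronger one. Compound 3 is therefore expected to stay level, with an estimated step of a number 1 percentage points lower from compound 2 to compound 3 (within the scatter) within the scatter; the estimate for compound 3 is 93%, ranging from 80% to 102%.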

Compound 3, a percentage reported as activity, at one concentration (the size of the read-out at that concentration, not a potency): 60%
Compound 3: middle estimate off by 33 percentage points, on the high side, outside the stated range (below it).
By their numbers in this assay, from the lowest: compound 3; then compounds 1 and 2 (each within the scatter of the next).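

On a saturated chain carbon bound to an aromatic nitrogen, the chain is not a silent place in this assay: putting 1,2-dihydroxyethyl in place of 2-hydroxypropyl gives a number 34 percentage points lower from compound 2 to compound 3 (beyond the scatter) and, against the form with a drawn configuration, a number 34 percentage points lower from compound 1 to compound 3 (beyond the scatter). Compound 1 and compound 2 could show only that the way one stereocentre is drawn leaves the read-out unmoved, whereas this change to the chain itself brings a clearly stronger effect on the cells. Nothing measured here accounts for this step.

The compounds shown leave open whether the effect would grow or fade with a longer chain, an amine or a carboxylic acid at the same place. They also leave open whether a defined configuration in compound 3 would matter, as only compound 1 and compound 2 compare drawn forms.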